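Swapping a Hydroxyethoxy Tail for Trifluoromethyl: Cytotoxicity Outlook

The source may hold more compounds than are shown below. What is called first, only, known or untested is meant among the compounds shown, and "the series" means these compounds.

Compound 1: `CC(C)(CO)Cn1c(Cn2nc(S(C)(=O)=O)c3ccncc32)nc2cc(Cl)ccc21`; > 100000 nM
Compound 2: `CS(=O)(=O)c1nn(Cc2nc3cc(Cl)ccc3n2CCOCCO)c2cnccc12`; > 100000 nM

In an ADME assay on HEp-2 cells (Homo sapiens) for cytotoxicity, with a stated time of 4 days (a higher number here means that more compound is tolerated, a lower number that less compound is tolerated), compound 1 reaches only a limit, > 100000 nM. Compound 2 likewise reaches only a limit, > 100000 nM, so both values sit at the limit of > 100000 nM in this assay, at which 2 of the 2 values shown sit. Among the compounds with values here, the one measured step, a step that the two limits leave unreadable from compound 1 to compound 2, is therefore unreadable, and no measured value shows where compound 2 truly stands. Compound 3, `CS(=O)(=O)c1nn(Cc2nc3cc(Cl)ccc3n2CCC(F)(F)F)c2cnccc12`, carries trifluoromethyl in place of 2-hydroxyethoxy on a saturated chain carbon, two bonds along the chain from an aromatic nitrogen. With no readable step to draw on, compound 3 is expected to stay at the same limit, a step of a number no higher from compound 2 to compound 3 (the limit leaves the size open), giving an estimate of 100000 nM with a range from 30000 nM to 300000 nM.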

Compound 3, half-maximal cytotoxic concentration: > 100000 nM
Compound 3 ended at the assay's limit (the forecaster's own chance of this, stated with the estimate: 75%); the middle value sits exactly at the limit.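

In this assay, within the data shown here, compound 1, compound 2 and compound 3 all stop at a limit, so no step between them can be read. The compounds shown leave open at what concentration each would become cytotoxic, and whether changing the tail alters it.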